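Trimming the Ring Nitrogen Substituent from Benzyl to Methyl

The source may report more compounds than this note shows. Statements on the series, on what has been measured and on what is new or still open speak of the compounds shown alone.

In a functional assay on HCT-116 cells (Homo sapiens) for inhibition, read by CCK-8 assay, with a stated time of 72 h, tested at 20 uM (a higher number here means more inhibition of growth at the concentration tested, a lower number less inhibition of growth), the three measured compounds gave:

Compound 1, `CCOC(=O)/C=C1/C(=O)Nc2ccccc21`: 89.3%
Compound 2, `CC(C)(C)OC(=O)/C=C1/C(=O)Nc2ccccc21`: 89.5%
Compound 3, `CC(C)(C)OC(=O)/C=C1/C(=O)N(Cc2ccccc2)c2ccccc21`: 87.9%

Compound 3 has the lowest of the three numbers, yet its gaps to compound 1 and to compound 2 both lie within the scatter, so nothing separates them. Compound 4, `CN1C(=O)/C(=C/C(=O)OC(C)(C)C)c2ccccc21`, differs from compound 3 by hydrogen in place of phenyl on a saturated chain carbon bound to an amide-type nitrogen in a ring. Among the compounds with values here, two measured steps bear on it: a number 0.2 percentage points higher from compound 1 to compound 2 (within the scatter) and a number 1.6 percentage points lower from compound 2 to compound 3 (within the scatter), both within the scatter. Within the data shown here, the second is the closer guide, since it is the only step touching the amide-type nitrogen in a ring, and it stayed within the scatter. Going back from benzyl toward a smaller group on that nitrogen is therefore expected to give a number 0.1 percentage points higher from compound 3 to compound 4 (within the scatter), no step beyond the scatter. Compound 4 is estimated at 88%, with a range from 80% to 94%.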

Compound 4, percent growth inhibition at one concentration: 87.5%
Compound 4: the middle estimate sits 0.5 percentage points above what was measured, within the range that was stated.
By their numbers in this assay, from the lowest: compounds 4, 3, 1 and 2 (each within the scatter of the next).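

Cutting the benzyl group on the ring nitrogen back to methyl removes the phenyl with no effect beyond the scatter in this assay (a number 0.4 percentage points lower from compound 3 to compound 4 (within the scatter)), and methyl in place of the amide hydrogen also stays within it (a number 2 percentage points lower from compound 2 to compound 4 (within the scatter)). This nitrogen can therefore carry hydrogen, methyl or benzyl without a difference this read-out can separate. No evidence is available to explain this lack of separation.

As far as these compounds go, whether a longer chain ending in an amine or a carboxylic acid on this nitrogen would keep the number stays open. So does whether these compounds would separate at a lower concentration.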